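Shortening a Propyl Chain: Expected Effect on Clearance

This account rests on a few compounds, and the source may have more. Where it says the series, first, only, none or still open, it means among the compounds named here.

Of the compounds shown here, three have been tested in an ADME assay on cells (Hepatocyte, Homo sapiens) for metabolic stability, read by LC-MS, with a stated time of 60 min, tested at 1 uM; on this read-out lower numbers stand for slow clearance and higher numbers for fast clearance. Compound 1 `CCCN(c1cnc(C(=O)[C@H]2C[C@@H]2C(=O)O)c(OC)c1)c1ccc(F)c2ccccc12` gives 7.6 uL/min in this assay. Among the compounds with values here, compound 2 `CCN(c1cnc(C(=O)[C@H]2C[C@@H]2C(=O)O)c(OC)c1)c1ccc(F)c2ccccc12`, which carries hydrogen in place of methyl on a saturated chain carbon, two bonds along the chain from a nitrogen on an aromatic ring, gives 3.8 uL/min; the step of a 2.0-fold lower number from compound 1 to compound 2 (0.30 log units; within the scatter) is the only measured example of this change. Compound 3 `CCCN(c1cccc(C(F)(F)F)c1)c1cnc(C(=O)[C@H]2C[C@@H]2C(=O)O)c(OC)c1` gives 7.2 uL/min in this assay; the difference between its core and the core of compound 1 is not broken down here. Compound 4 `CCN(c1cccc(C(F)(F)F)c1)c1cnc(C(=O)[C@H]2C[C@@H]2C(=O)O)c(OC)c1` is not yet measured and differs from compound 3 by hydrogen in place of methyl on a saturated chain carbon, two bonds along the chain from a nitrogen on an aromatic ring, the same change seen between compound 1 and compound 2. Resting on the step from compound 1 to compound 2, compound 4 is expected to show a step of a 2.0-fold lower number from compound 3 to compound 4 (0.30 log units; within the scatter). The estimate for compound 4 is 3.6 uL/min, between 1.8 uL/min and 7.2 uL/min.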

Compound 4, intrinsic clearance in a liver preparation (reported as CLH), per the amount of preparation that the assay uses in the Hepatocyte assay: 3.1 uL/min
Compound 4: the middle estimate sits 1.2-fold (0.06 log units) above what was measured; low and high end bracket the measured number.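

In the Hepatocyte assay the change from propyl to ethyl gives a 2.3-fold lower number from compound 3 to compound 4 (0.37 log units; beyond the scatter), so it carries over to the second core at much the same size: the same change on two cores in the Hepatocyte assay, a 2.0-fold lower number (0.30 log units; within the scatter) from compound 1 to compound 2 and a 2.3-fold lower number (0.37 log units; beyond the scatter) from compound 3 to compound 4, 1.2-fold (0.06 log units) apart, within the scatter of two such steps

In a physicochemical assay for lipophilicity, read by LC-MS, in phosphate buffer, measured as octanol-water partition, at pH 7.4 (on this read-out lower numbers stand for lower lipophilicity and higher numbers for higher lipophilicity), compound 3 gives 1.2 and compound 4 gives 0.7. Two pairs cannot show why the clearance numbers move, whether the lower distribution coefficient plays any part, or whether the step would hold on any further core.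

The compounds shown leave open how a longer chain such as butyl, or a shorter one such as methyl, would read in place of the propyl in the Hepatocyte assay. They also leave open whether a chain carrying an amine would follow the same trend.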